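A few compounds are considered here, and "the series" means these few. Any claim that something is new, unique, unknown or untested is made for them only; others in the source may bear on it.

Compound 1, `NC(=[Se])N/N=C/c1ccc(Cl)cc1`, was examined in a functional assay on HepG2 cells (Homo sapiens) for cytotoxicity, read by XTT assay, with a stated time of 72 h (a higher number here means a weaker inhibitor, a lower number a stronger inhibitor), where compound 1 gives 13000 nM. Compound 2, `COc1ccc(/C=N/NC(N)=[Se])cc1`, differs from compound 1 by methoxy in place of chloro on an aromatic carbon; in this assay compound 2 gives 11300 nM, and the step of a 1.2-fold lower number from compound 1 to compound 2 (0.06 log units; within the scatter) lies within the scatter. Compound 3, `CC(=O)N(/N=C/c1ccc(Cl)cc1)c1nc(C)c[se]1`, belongs to a different core, and the difference between the two cores is not broken down here; in this assay compound 3 gives 59200 nM, the highest number of the three.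

Compound 4, `COc1ccc(/C=N/N(C(C)=O)c2nc(C)c[se]2)cc1`, is not yet measured. It differs from compound 3 by methoxy in place of chloro on an aromatic carbon. This is the same kind of change as that between compound 1 and compound 2, though the place differs in its surroundings: in compound 3 the aromatic carbon is para to a large group, in compound 1 it is para to a group of 6 heavy atoms. Because the earlier step of a 1.2-fold lower number from compound 1 to compound 2 (0.06 log units; within the scatter) was within the scatter, a similarly small step is expected for compound 4 in this assay. That expectation corresponds to a step of a 1.1-fold lower number from compound 3 to compound 4 (0.06 log units; within the scatter). Compound 4 is thus estimated at 52000 nM, between 24000 nM and 115000 nM.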

Compound 4, half-maximal inhibitory concentration: > 74300 nM
Compound 4: only a limit was reported; the forecaster's own chance of this, stated with the estimate: 10%; middle value at least 1.4-fold (0.15 log units) away from the limit.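

In this assay compound 4 gave only a limit, > 74300 nM, and not a number. Taken as a floor, methoxy in place of chloro gives an at least 1.2-fold higher number from compound 3 to compound 4 (0.09 log units; that floor lies within the scatter), so the data show no lowering of the number on the core of compound 3, but they do not fix the size of the step, which may be small or much larger. Whether the change carries over from one core to the other with the same size therefore stays undecided, neither confirmed nor refuted: the same change on two cores in this assay, a 1.2-fold lower number (0.06 log units; within the scatter) from compound 1 to compound 2 and an at least 1.2-fold higher number (0.09 log units; that floor lies within the scatter) from compound 3 to compound 4; the limit leaves it open whether they differ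

The compounds shown carry only chloro and methoxy at this aromatic carbon, so it remains open how an amine, a carboxylic acid or a longer alkoxy chain in that place would read in this assay on either core. Also open is what the acetyl group on the core of compound 3 contributes to its 59200 nM, as no compound shown lacks that group on that core.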